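Replacing (3-(dimethylamino)propyl)sulfanyl with isopropoxy on the shared core

The compounds below may be only part of what the source reports. "The series", "measured", "known", "first", "only" and "open" are said of these compounds alone.

Of the compounds shown here, three sharing one core have been measured in a functional assay on MV4-11 cells (Homo sapiens) for inhibition, read by resazurin assay, with a stated time of 72 h; a higher number here means a weaker inhibitor of growth, a lower number a stronger inhibitor of growth. Compound 1 `COc1ccc(Nc2nccc(-c3sc(SC(C)C)nc3C)n2)c(OC)c1` gives 5670 nM, compound 2 `COc1ccc(Nc2nccc(-c3sc(OC)nc3C)n2)c(OC)c1` gives 1400 nM, and compound 3 `COc1ccc(Nc2nccc(-c3sc(SCCCN(C)C)nc3C)n2)c(OC)c1` gives 370 nM, the lowest number of the three. Compound 4 `COc1ccc(Nc2nccc(-c3sc(OC(C)C)nc3C)n2)c(OC)c1` has not yet been measured. It carries isopropoxy in place of (3-(dimethylamino)propyl)sulfanyl on an aromatic carbon.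

Going by the values given here, three measured steps bear on this change. Putting 3-(dimethylamino)propyl in place of isopropyl on a sulfur gave a 15-fold lower number from compound 1 to compound 3 (1.19 log units; beyond the scatter), a large step. Putting (3-(dimethylamino)propyl)sulfanyl in place of methoxy gave a 3.8-fold lower number from compound 2 to compound 3 (0.58 log units; beyond the scatter), a modest one. Methoxy in place of isopropylsulfanyl gave a 4.1-fold lower number from compound 1 to compound 2 (0.61 log units; beyond the scatter), also modest. Both compounds without the dimethylamino group have higher numbers than compound 3, and compound 4 lacks that group too. A modest to large rise in this assay is therefore expected. Among the compounds with values here, no isopropoxy compound has been measured, but the group shares its isopropyl with compound 1, at 5670 nM, and its attachment through oxygen with compound 2, at 1400 nM, so a number between these two seems likely. The expected change is a 7.6-fold higher number from compound 3 to compound 4 (0.88 log units; beyond the scatter). Compound 4 is estimated at 2800 nM, with an expected range of 1100 nM to 7000 nM.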

Compound 4, concentration for 50% growth inhibition: 8690 nM
The estimate for compound 4 lay 3.1-fold (0.49 log units) below the measured number; the whole stated range lies below it.
By their numbers in this assay, from the lowest: compound 3; then compound 2; then compounds 1 and 4 (each within the scatter of the next).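

With the isopropyl kept, isopropoxy in place of isopropylsulfanyl gave a 1.5-fold higher number from compound 1 to compound 4 (0.19 log units; within the scatter) in this assay, so among these isopropyl compounds, exchanging sulfur for oxygen at this aromatic carbon made no difference beyond the scatter. With the oxygen kept, isopropyl in place of methyl gave a 6.2-fold higher number from compound 2 to compound 4 (0.79 log units; beyond the scatter), which shows that the group on the oxygen matters here, while the full change from (3-(dimethylamino)propyl)sulfanyl to isopropoxy gave a 23-fold higher number from compound 3 to compound 4 (1.37 log units; beyond the scatter), leaving compound 3 as the only one of the four with a number this low. Nothing available explains these differences in growth inhibition.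

The compounds shown leave open whether the low number of compound 3 follows from the dimethylamino group itself or from the length of its chain, a question that a plain butyl chain on the sulfur or a shorter 2-(dimethylamino)ethyl chain would address. They also leave open whether the amine keeps its effect when attached through oxygen, as in 3-(dimethylamino)propoxy, and whether a morpholine or a carboxylic acid at the chain end would behave like the dimethylamino group.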